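A few compounds are considered here, and "the series" means these few. Any claim that something is new, unique, unknown or untested is made for them only; others in the source may bear on it.

Measured compounds:
- compound 1, `CCc1nc(-c2ccc(Cl)cc2Cl)c(CC)nc1NC(CC)CC`, gives 0.07 h in an in vitro ADME assay on microsomes (Rattus norvegicus) for metabolic stability; on this read-out lower numbers stand for a shorter-lived compound and higher numbers for a longer-lived compound
- compound 2, `CCOc1nc(-c2ccc(Cl)cc2Cl)c(CC)nc1NC(CC)CC`, gives 1.23 h in this assay
- compound 3, `CCc1nc(-c2ccc(Cl)cc2Cl)c(OC)nc1NC(CC)CC`, gives 0.183 h in this assay

Compound 1 stands lowest of the three numbers in this assay: compound 3 lies closest, and compound 2 furthest. The two measured steps both change a group on the core, with an 18-fold higher number from compound 1 to compound 2 (1.24 log units; beyond the scatter) and a 2.6-fold higher number from compound 1 to compound 3 (0.42 log units; beyond the scatter), ethoxy and methoxy taking the place of an ethyl.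

Compound 4, `CCCN(CC1CC1)c1nc(CC)c(-c2ccc(Cl)cc2Cl)nc1CC`, differs from compound 1 elsewhere: (cyclopropylmethyl)(propyl)amino in place of (pentan-3-yl)amino on an aromatic carbon. Within the data shown here, no measured step touches this amino group, so neither of the two steps above bears directly on the change; they only show that the number of compound 1 can move upward by a modest or a large amount when a group on the core is exchanged. With no guidance of this kind for the amino group, the expected step of a 1.4-fold higher number from compound 1 to compound 4 (0.15 log units; within the scatter) is small and within the scatter, with wide uncertainty in both directions. Compound 4 is therefore estimated at 0.1 h in this assay, in a range from 0.03 h to 0.4 h.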

Compound 4, half-life: 0.07 h
The estimate for compound 4 lay 1.4-fold (0.15 log units) above the measured number; measured number inside the range.
By their numbers in this assay, from the lowest: compounds 1 and 4 (each within the scatter of the next); then compound 3; then compound 2.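

Placing (cyclopropylmethyl)(propyl)amino where (pentan-3-yl)amino stood, on the aromatic carbon next to the ring nitrogen, gives no change at the digits printed from compound 1 to compound 4 (within the scatter) in this assay. Among these compounds, this is the first measured change at this position: the entering group is larger, carries a three-membered ring and has no hydrogen-bond donor, yet the half-life stays short, whereas the two earlier steps, both exchanges of an ethyl group on the core, each raised the number beyond the scatter. Nothing available explains why this exchange leaves the number in place.

Still open, from the compounds shown here alone, is whether the same amino exchange would leave the number unchanged on the ethoxy-bearing core of compound 2. Going by these compounds, it is also open whether an amino group containing oxygen, such as morpholine, would behave like these two all-carbon substituents at this position.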